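Pyrimidine diamines: swapping the aryl substituent on compound 2

This account rests on a few compounds, and the source may have more. Where it says the series, first, only, none or still open, it means among the compounds named here.

Measured compounds:
compound 1 `CCOC(=O)c1ccc(Nc2cc(NC(=O)CCCC(=O)O)ncn2)cc1`: 69 nM
compound 2 `COc1cccc(Nc2cc(Nc3ccc(S(N)(=O)=O)cc3)ncn2)c1`: 1850 nM
compound 3 `COc1ccc(OC)c(Nc2cc(Nc3ccc(S(N)(=O)=O)cc3)ncn2)c1`: 619 nM

In an assay for inhibition of Receptor tyrosine-protein kinase erbB-3 variant L858R (Homo sapiens), read by mobility shift assay, with a stated time of 10 min (a lower number here means a stronger inhibitor, a higher number a weaker inhibitor), compound 2 gives the highest of the three numbers, with compound 3 the nearest and compound 1 the furthest below it. Within the measured pairs, the only single-site step is a 3.0-fold lower number from compound 2 to compound 3 (0.48 log units; beyond the scatter), a change on the methoxy-bearing ring that does not touch the group exchanged here.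

Compound 4 `CCOC(=O)c1ccc(Nc2cc(Nc3cccc(OC)c3)ncn2)cc1` differs from compound 2 by ethoxycarbonyl in place of sulfamoyl on an aromatic carbon, sitting on an aromatic carbon of a six-membered aromatic ring of carbon only, para to a large group. Within the data shown here, no measured pair isolates this exchange. Compound 1 also carries ethoxycarbonyl on its aryl amine and gives 69 nM, far below compound 2, but compound 1 differs from compound 2 at a second site as well, so this comparison is only indicative.

On that indication, a lower number is expected for compound 4, with wide uncertainty; the step from compound 2 is estimated as a 5.3-fold lower number from compound 2 to compound 4 (0.72 log units; beyond the scatter). The estimate for compound 4 is 350 nM, with a range from 70 nM to 1800 nM.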

Compound 4, half-maximal inhibitory concentration: 1750 nM
Estimate against measurement, compound 4: 5.0-fold (0.70 log units) below; the measured number falls inside the stated range.
By their numbers in this assay, from the lowest: compound 1; then compound 3; then compounds 4 and 2 (each within the scatter of the next).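

In this assay, the step of a 1.1-fold lower number from compound 2 to compound 4 (0.02 log units; within the scatter) shows that, with 3-methoxyphenyl on the other nitrogen, this assay does not separate sulfamoyl from ethoxycarbonyl on this aromatic carbon, para to a large group. Ethoxycarbonyl alone therefore does not account for the low number of compound 1: with that group held constant, the step of a 25-fold higher number from compound 1 to compound 4 (1.40 log units; beyond the scatter) goes with the exchange of (3-carboxypropyl)carbonyl for 3-methoxyphenyl on the nitrogen, the first single-site sign that this second site carries a large difference in this series. No available evidence gives a reason for either step.

As far as these compounds go, it remains open whether sulfamoyl and ethoxycarbonyl also stay level when the nitrogen carries (3-carboxypropyl)carbonyl or when the aryl group carries the second methoxy of compound 3, since the exchange has been read against only one partner. Also open, from the compounds shown here alone, are which part of the (3-carboxypropyl)carbonyl group goes with the low number, as a shorter acyl chain or a methyl ester in place of its carboxylic acid would show, and how a nitrile or a primary amine would read on the aromatic carbon.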